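The source may report more compounds than this note shows. Statements on the series, on what has been measured and on what is new or still open speak of the compounds shown alone.

Compound 2 `O=[N+]([O-])c1ccc(/C=N/Nc2nc3ccccc3nc2Cc2ccccc2)cc1` gives the higher of the two numbers recorded so far in an assay on isolated protein for inhibition of Amine oxidase [flavin-containing] B (Homo sapiens), read by spectrophotometry (a higher number here means a weaker inhibitor, a lower number a stronger inhibitor), with a half-maximal inhibitory concentration of 960000 nM. Its nearest neighbour on that scale is compound 1 `C/C(=N\Nc1nc2ccccc2nc1Cc1ccccc1)c1cccs1`, which in this assay gives 850000 nM; the two values lie within the usual scatter of each other, so neither can be called the weaker. Compound 3 `Brc1cccc(/C=N/Nc2nc3ccccc3nc2Cc2ccccc2)c1` has not yet been measured in this assay. The change from compound 2 is 3-bromophenyl in place of 4-nitrophenyl on a carbon with a double bond to nitrogen. Going by the values given here, no step between measured compounds covers such a change, so there is nothing in these numbers to anchor a direction. With both measured values sitting at the very weak end of the scale, compound 3 is expected to give a number of a similar order, and the estimated step from compound 2 is a 1.6-fold lower number from compound 2 to compound 3 (0.20 log units; within the scatter), a move not clearly beyond the scatter. Compound 3 is therefore estimated at 600000 nM, within a range from 150000 nM to 2500000 nM.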

Compound 3, half-maximal inhibitory concentration: 48000 nM
Compound 3: the middle estimate sits 13-fold (1.10 log units) above what was measured; the whole stated range lies above it.
By their numbers in this assay, from the lowest: compound 3; then compounds 1 and 2 (each within the scatter of the next).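

In this assay the substituent on the carbon with a double bond to nitrogen proves able to shift the number strongly: 3-bromophenyl in place of 4-nitrophenyl gives a 20-fold lower number from compound 2 to compound 3 (1.30 log units; beyond the scatter) and sets compound 3 clearly apart, which the two earlier values, within the scatter of each other, could not show. The larger exchange at the nitrogen on an aromatic ring gives an 18-fold lower number from compound 1 to compound 3 (1.25 log units; beyond the scatter) and places compound 3 clear of compound 1 as well. No measurement here accounts for the drop.

The exchange alters both the substituent and its place on the phenyl ring, so the compounds shown do not separate these two changes. They also leave open how a plain phenyl, or a phenyl carrying an amine or a carboxylic acid, would compare.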